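Adding a second fluorine to a nitrile-bearing quinoline

The source may report more compounds than this note shows. Statements on the series, on what has been measured and on what is new or still open speak of the compounds shown alone.

Of the compounds shown here, three share a common core and have been measured in a physicochemical assay for lipophilicity, using the shake flask method; on this read-out higher numbers stand for higher lipophilicity and lower numbers for lower lipophilicity. Compound 3 `C[C@H](Oc1cc2cc(C(N)=O)ccc2nc1N)c1cc(F)ccc1-n1cccn1` gives 3. Compound 1 `C[C@H](Oc1cc2cc(C(N)=O)ccc2nc1N)c1cc(F)c(F)cc1-n1cccn1` gives 3.2. Compound 2 `C[C@H](Oc1cc2cc(C#N)ccc2nc1N)c1cc(F)ccc1-n1cccn1` gives 3.8 in this assay, the highest of the three. The change from compound 3 to compound 1 is fluoro in place of hydrogen on an aromatic carbon and it moved the read-out by a number 0.20 log units higher from compound 3 to compound 1 (within the scatter). Compound 2 and compound 3 differ in their cores by cyano in place of carbamoyl on an aromatic carbon, a step of a number 0.80 log units lower from compound 2 to compound 3 (beyond the scatter). Compound 4 `C[C@H](Oc1cc2cc(C#N)ccc2nc1N)c1cc(F)c(F)cc1-n1cccn1` is not yet measured; it differs from compound 2 by fluoro in place of hydrogen on an aromatic carbon, the same change seen between compound 3 and compound 1. Because that change gave a number 0.20 log units higher from compound 3 to compound 1 (within the scatter), a similar step of a number 0.20 log units higher from compound 2 to compound 4 (within the scatter) is expected from compound 2 to compound 4. Compound 4 is therefore estimated at 4, likely between 3.7 and 4.3.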

Compound 4, distribution coefficient: 4.3
Beside the measured number, compound 4's estimate is 0.30 log units below it, and the stated range covers the measured number.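

In this assay, the added fluoro gave a number 0.50 log units higher from compound 2 to compound 4 (beyond the scatter) on the nitrile-bearing core, while the same change on the carbamoyl-bearing core gave a number 0.20 log units higher from compound 3 to compound 1 (within the scatter) and so cannot be told from scatter. Going by these compounds alone, with the second fluoro present, nitrile in place of carbamoyl gave a number 1.10 log units higher from compound 1 to compound 4 (beyond the scatter) in this assay, yet a single pair on each core shows only that the fluoro step clears the scatter on one core, not that its true size depends on the core. No measurement shown here explains this result.

The compounds shown leave open whether a chlorine or methyl group at the same aromatic carbon would behave like fluoro. They also leave open how that change would act on a core carrying an amine or a carboxylic acid in place of the nitrile.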